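A few compounds are considered here, and "the series" means these few. Any claim that something is new, unique, unknown or untested is made for them only; others in the source may bear on it.

Measured in a functional assay on a cell-free system (plasma, Oryctolagus cuniculus) for inhibition, with stated times of 5 min, 1 min and 6 min; on this read-out higher numbers stand for weaker inhibition and lower numbers for stronger inhibition:

- Compound 1 `CCOC(=O)c1c(C)nc(-c2cccc(C#N)c2)n1O`: 17600 nM
- Compound 2 `CCOC(=O)c1c(C)nc(-c2cccc(C#N)c2)n1OC`: 9130 nM
- Compound 3 `CCOC(=O)c1c(C)nc(-c2cccc(C#N)c2)n1C(C)C`: 9260 nM

All three compounds share one core and differ only in the group on an aromatic nitrogen. In this assay compound 3 gives 9260 nM, and this value does not stand apart from the other two, so the three cannot be ranked.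

Compound 4 `CCOC(=O)c1c(C)nc(-c2cccc(C#N)c2)n1OC(C)C` has not yet been measured. Its change from compound 3 is isopropoxy in place of isopropyl on an aromatic nitrogen, which is isopropoxy in place of isopropyl on an aromatic nitrogen.

Among the measured compounds shown here, no measured step makes exactly this swap, but three steps at the same nitrogen bear on it. Putting methyl on the oxygen gives a 1.9-fold lower number from compound 1 to compound 2 (0.29 log units; within the scatter). Isopropyl in place of hydroxy gives a 1.9-fold lower number from compound 1 to compound 3 (0.28 log units; within the scatter). Isopropyl in place of methoxy gives a 1.0-fold higher number from compound 2 to compound 3 (0.01 log units; within the scatter). None of these three steps leaves the scatter, so the data offer no reason to expect a real shift, and they give no direction for one.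

The expected result is a 1.0-fold lower number from compound 3 to compound 4 (0.01 log units; within the scatter), which would be no real change. For compound 4 the estimated value is 9000 nM, with an expected range from 4500 nM to 18000 nM.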

Compound 4, half-maximal inhibitory concentration: 6740 nM
Beside the measured number, compound 4's estimate is 1.3-fold (0.13 log units) above it; the range from low to high includes it.
By their numbers in this assay, from the lowest: compounds 4, 2, 3 and 1 (each within the scatter of the next, the first and the last beyond it).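

In this assay, two of the new comparisons stay within the scatter: putting an oxygen between the ring nitrogen and the isopropyl group gives a 1.4-fold lower number from compound 3 to compound 4 (0.14 log units; within the scatter), and isopropyl in place of methyl on that oxygen gives a 1.4-fold lower number from compound 2 to compound 4 (0.13 log units; within the scatter). Among the compounds shown here, the new information comes from the hydroxy compound, where isopropyl in place of the hydrogen on the oxygen gives a 2.6-fold lower number from compound 1 to compound 4 (0.42 log units; beyond the scatter), the first step at this nitrogen to leave the scatter, though only modestly. Compounds 2 and 3 each remain within the scatter of both compound 1 and compound 4, so this one separated pair does not establish a graded trend across the four groups.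

Nothing shown explains why compound 1 and compound 4 separate. Still open, as far as these compounds go, is how this assay would respond to a longer chain on the oxygen, such as butoxy, or to a carboxylic acid or an amine carried at the end of that chain.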